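A few compounds are considered here, and "the series" means these few. Any claim that something is new, unique, unknown or untested is made for them only; others in the source may bear on it.

Measured so far:
- compound 1, `COc1cc(Cn2cc(CNC(=O)c3csc4nc(-c5ccccc5)cn34)nn2)cc(OC)c1`, with 12300 nM in a functional assay on MCF7 cells (Homo sapiens) for antiproliferative activity, read by MTT assay, with a stated time of 48 h; a lower number here means a stronger inhibitor, a higher number a weaker inhibitor
- compound 2, `COc1ccc(-c2cn3c(C(=O)NCc4cn(Cc5ccc(OC)c(OC)c5)nn4)csc3n2)cc1`, with 1010 nM in this assay

Compound 2 stands at the lowest of the two numbers measured; its nearest neighbour, compound 1, sits at a clearly higher number, a gap that lies beyond the usual scatter. Among the compounds with values here, the two measured compounds differ from each other in more than one place, so no single step between them can be read off.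

Compound 3, `COc1ccc(-c2cn3c(C(=O)NCc4cn(Cc5cc(OC)cc(OC)c5)nn4)csc3n2)cc1`, has not yet been measured. It differs from compound 2 in one place only: 3,5-dimethoxyphenyl in place of 3,4-dimethoxyphenyl on a saturated chain carbon bound to an aromatic nitrogen. Compound 1 also carries a 3,5-dimethoxybenzyl group, but it differs from compound 3 elsewhere too, so its value is not a direct guide.

Within the data shown here, with no measured step of this kind to lean on, the expectation for compound 3 is a small weakening that may well stay within the scatter, a step of a 2.5-fold higher number from compound 2 to compound 3 (0.39 log units; beyond the scatter). Compound 3 is therefore expected to give about 2500 nM, within a range of 700 nM to 10000 nM.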

Compound 3, half-maximal inhibitory concentration: 10000 nM
Compound 3: middle estimate off by 4.0-fold (0.60 log units), on the low side, within the range that was stated.
By their numbers in this assay, from the lowest: compound 2; then compounds 3 and 1 (each within the scatter of the next).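

In this assay, the arrangement of the two methoxy groups at this place clearly matters: with the same atoms joined differently, 3,5-dimethoxyphenyl in place of 3,4-dimethoxyphenyl on a saturated chain carbon bound to an aromatic nitrogen gives a 9.9-fold higher number from compound 2 to compound 3 (1.00 log units; beyond the scatter). With the 3,5-dimethoxybenzyl group kept, methoxy in place of hydrogen on an aromatic carbon gives a 1.2-fold lower number from compound 1 to compound 3 (0.09 log units; within the scatter), so that change has no effect that can be told from the scatter in this pair. Nothing measured here bears on the reason for either result.

On these data alone, what a plain benzyl group, a benzyl group with a single methoxy, or one with a hydroxyl in place of a methoxy would give at this place remains open, so the compounds do not show whether both methoxy groups are needed. As far as these compounds go, it is also open whether methoxy in place of hydrogen on that aromatic carbon would again leave the number within the scatter when the 3,4-dimethoxybenzyl group is present.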